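The source may report more compounds than this note shows. Statements on the series, on what has been measured and on what is new or still open speak of the compounds shown alone.

Working notes on the series.

Compound 1 `COc1cc(-c2cc(/C=C/C(=O)c3ccc(C)c(C)c3)nc3cc(-c4ccccc4)nn23)cc(OC)c1OC` is the reference point. In a functional assay on A549 cells (Homo sapiens) for antiproliferative activity, read by MTT assay, with a stated time of 24 h (a lower number here means a stronger inhibitor, a higher number a weaker inhibitor), compound 1 gives 10600 nM. Two analogues with the same core are available for comparison: compound 2 `COc1ccc(C(=O)/C=C/c2cc(-c3ccc(OC)c(OC)c3)n3nc(-c4ccccc4)cc3n2)cc1` gives 11900 nM in this assay, and compound 3 `COc1ccc(-c2cc(C(=O)/C=C/c3ccccc3)nc3cc(-c4ccccc4)nn23)cc1OC` gives 18600 nM. Compound 1 has the lowest of the three numbers, but its gaps to compound 2 and to compound 3 are both within the scatter, so no order among the three can be claimed from these values. Among the compounds with values here, the only single-point step measured within the set, a 1.6-fold higher number from compound 2 to compound 3 (0.19 log units; within the scatter), also stayed within the scatter.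

Compound 4 `COc1cc(-c2cc(/C=C/C(=O)c3ccc(C)cc3)nc3cc(-c4ccccc4)nn23)cc(OC)c1OC` differs from compound 1 by hydrogen in place of methyl on an aromatic carbon. Within the data shown here, no measured step touches this position; the one measured step concerns a different part of the molecule and was flat. With nothing in the series pointing either way, the expected outcome is no step beyond the scatter, a 1.0-fold higher number from compound 1 to compound 4 (0.02 log units; within the scatter). For compound 4 the estimate in this assay is 11000 nM, with a range from 6000 nM to 20000 nM.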

Compound 4, half-maximal inhibitory concentration: 19400 nM
For compound 4 the middle estimate is 1.8-fold (0.25 log units) below the measured one, within the range that was stated.
By their numbers in this assay, from the lowest: compounds 1, 2, 3 and 4 (each within the scatter of the next).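

Within the data shown here, this is the first measured step at this position, from 3,4-dimethylphenyl to 4-methylphenyl: in this assay the change gives a 1.8-fold higher number from compound 1 to compound 4 (0.26 log units; within the scatter) and so claims no change in either direction. On this aromatic carbon, ortho to a methyl group and meta to a large group, methyl and hydrogen therefore cannot be told apart in this assay, on the evidence of this one pair. No independent measurement bears on the result or offers an account of it.

Only methyl and hydrogen appear at this carbon among the compounds shown, so what an amine or a carboxylic acid there would do remains open. Also open, going by these compounds, is whether the same change would read alike with the other substituents carried by compound 2 and compound 3.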